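Trimming the Styryl Ring to a Bare Hydroxyphenyl

A few compounds are considered here, and "the series" means these few. Any claim that something is new, unique, unknown or untested is made for them only; others in the source may bear on it.

Compound 2 `COc1cc(/C=C/C(=O)c2cccc(-n3cc(-c4ccccc4)[nH]c3=O)c2)ccc1O` and compound 1 `COc1cc(/C=C/C(=O)c2cccc(-n3cc(-c4ccc(Cl)cc4)[nH]c3=O)c2)cc(OC)c1OC` share one core and were both tested in a functional assay on NCI-H460 cells (Homo sapiens) for inhibition; a lower number here means a stronger inhibitor of growth, a higher number a weaker inhibitor of growth. Compound 2 gives 1950 nM, the lower of the two numbers, while compound 1 gives 3740 nM; the gap between them stays within the usual scatter. Compound 3 `O=C(/C=C/c1cccc(O)c1)c1cccc(-n2cc(-c3ccccc3)[nH]c2=O)c1` has not been measured yet. It differs from compound 2 by 3-hydroxyphenyl in place of 4-hydroxy-3-methoxyphenyl on a double-bonded chain carbon bound to a double-bonded chain carbon. For the measured compounds named here, no measured pair shows this change, so no step beyond the scatter is expected in either direction in this assay. Compound 3 is therefore estimated at 2500 nM, with a range from 800 nM to 8000 nM. The expected step of a 1.3-fold higher number from compound 2 to compound 3 (0.11 log units; within the scatter) is close to none.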

Compound 3, concentration for 50% growth inhibition: 2490 nM
For compound 3 the middle estimate is 1.0-fold (0.00 log units) above the measured one; the range from low to high includes it.
By their numbers in this assay, from the lowest: compounds 2, 3 and 1 (each within the scatter of the next).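

For the compounds shown here, replacing 4-hydroxy-3-methoxyphenyl with 3-hydroxyphenyl gives the first measured step at this position, a 1.3-fold higher number from compound 2 to compound 3 (0.11 log units; within the scatter), in this assay. This styryl ring can therefore be trimmed to 3-hydroxyphenyl, losing the methoxy group, without a shift beyond the scatter. No evidence is available on what lies behind this result.

Still open, as far as these compounds go, is whether a group of a different kind, such as an amine or a carboxylic acid in place of the hydroxyl, would shift the number. A bare phenyl ring at this position also remains to be seen.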